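The source may report more compounds than this note shows. Statements on the series, on what has been measured and on what is new or still open speak of the compounds shown alone.

Measured in an ADME assay on HEK293 cells (Homo sapiens) for cytotoxicity, with a stated time of 72 h; a lower number here means that less compound is needed, a higher number that more compound is needed for the effect:
- compound 1 `C=C[C@@](C)(/C=C/c1ccc(OCc2ccccc2)cc1)CCC=C(C)C`: > 36600 nM, a limit
- compound 2 `C=C[C@@](C)(/C=C/c1ccc(O)cc1)CCC(O)C(C)(C)O`: > 36600 nM, a limit

Compound 2 has no exact number here, only a limit. Both measured compounds share it: the limit of > 36600 nM in this assay, at which 2 of the 2 values shown sit. Among the measured compounds shown here, no measured step is available. Compound 3 `C=C[C@@](C)(/C=C/c1ccc(O)cc1)CC/C=C/C#N` differs from compound 2 by 2-cyanoethenyl in place of 1,2-dihydroxy-2-methylpropyl on a saturated chain carbon, three bonds along the chain from two double-bonded chain carbons: 2-cyanoethenyl in place of 1,2-dihydroxy-2-methylpropyl on a saturated chain carbon. No change beyond the scatter is expected in this assay, because the limit of > 36600 nM in this assay, at which 2 of the 2 values shown sit, is all the series shows so far. The expected at least 1.2-fold lower number from compound 2 to compound 3 (0.08 log units; that floor lies within the scatter) is therefore small. For compound 3 the estimate is 30000 nM, with an expected range of 10000 nM to 60000 nM.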

Compound 3, half-maximal effective concentration: > 36600 nM
Compound 3: no number, only a limit (the forecaster's own chance of this, stated with the estimate: 65%); middle value at least 1.2-fold (0.08 log units) from the limit.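

Compound 2 and compound 3 both give only a limit, so no step between them can be read in this assay: the limit of > 36600 nM in this assay, at which 3 of the 3 values shown sit.

The compounds shown leave open where any of them would give an exact number in this assay.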